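The source may hold more compounds than are shown below. What is called first, only, known or untested is meant among the compounds shown, and "the series" means these compounds.

In a functional assay on U-937 cells (Homo sapiens) for antiproliferative activity, read by MTT assay, with a stated time of 24 h (a lower number here means a stronger inhibitor, a higher number a weaker inhibitor), compound 1 `CNC(=O)c1ccccc1Oc1nc(Nc2ccccc2F)ncc1Br` gives > 50000 nM which is a limit of the assay and not a number. Among the compounds with values here, compound 2 `CNC(=O)c1ccccc1Oc1nc(Nc2cccc(C)c2)ncc1Br` gives 15900 nM as the only true number so far, which makes it the single firm reference point. Compound 3 `CCOc1ccccc1Oc1nc(Nc2cccc(C)c2)ncc1Br` differs from compound 2 in one place, with ethoxy in place of methylcarbamoyl on an aromatic carbon. Within the data shown here, the one measured step of an at least 3.1-fold lower number from compound 1 to compound 2 (0.49 log units; beyond the scatter) came with 3-methylphenyl in place of 2-fluorophenyl on a nitrogen on an aromatic ring, which is a change elsewhere in the molecule. Among the measured compounds shown here, no measured step touches the methylcarbamoyl group, so neither size nor direction can be read from the data. The estimated step of a 1.1-fold lower number from compound 2 to compound 3 (0.06 log units; within the scatter) is therefore expected to stay within the usual scatter in this assay although the uncertainty is wide. For compound 3 the expected value is 14000 nM with an estimated range from 4000 nM to 45000 nM as its upper end.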

Compound 3, half-maximal inhibitory concentration: 38600 nM
For compound 3 the middle estimate is 2.8-fold (0.44 log units) below the measured one; the measured number falls inside the stated range.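

Within the data shown here, this is the first measured change at this position, on an aromatic carbon ortho to a large group. In this assay, ethoxy in place of methylcarbamoyl gives a 2.4-fold higher number from compound 2 to compound 3 (0.39 log units; beyond the scatter), so with the 3-methylphenyl group kept, what sits here does alter the result, though only modestly. The swap removes the hydrogen-bond donor of the methylcarbamoyl group, yet compound 3 still gives a true number, whereas compound 1 stands at a limit of the assay and not a number: the limit of > 50000 nM in this assay, at which 1 of the 3 values shown sits.

A single swap cannot show whether the missing hydrogen-bond donor or some other difference between the two groups accounts for the step. On these data alone, how a primary amide, a carboxylic acid or a longer chain such as propoxy would behave at this position remains open.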